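Methoxy for Fluoro on the Pyrazole-Linked Phenyl

This account rests on a few compounds, and the source may have more. Where it says the series, first, only, none or still open, it means among the compounds named here.

Three compounds have numbers in a functional assay on HT-29 cells (Homo sapiens) for antiproliferative activity, read by MTT assay, with a stated time of 48 h; a higher number here means a weaker inhibitor, a lower number a stronger inhibitor:
Compound 1, `O=C(/C=C\Nc1ccc(F)cc1)c1cn(-c2ccccc2)nc1-c1ccc(F)cc1`, gives 6500 nM.
Compound 2, `O=C(/C=C\Nc1ccc(C(F)(F)F)cc1)c1cn(-c2ccccc2)nc1-c1ccc(F)cc1`, gives > 50000 nM, which is a limit of this assay and not a number.
Compound 3, `COc1cc(N/C=C\C(=O)c2cn(-c3ccccc3)nc2-c2ccc(F)cc2)cc(OC)c1OC`, gives 7770 nM.

Compound 3 sits beside compound 1, the two numbers lying within the usual scatter of each other. Compound 2 reaches only (the limit of > 50000 nM in this assay, at which 1 of the 3 values shown sits). Among the compounds with values here, the one measured step, an at least 7.6-fold higher number from compound 1 to compound 2 (0.88 log units; beyond the scatter), shows a change on the aniline part of the shared core and lies beyond the scatter.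

Compound 4, `COc1ccc(-c2nn(-c3ccccc3)cc2C(=O)/C=C\Nc2cc(OC)c(OC)c(OC)c2)cc1`, differs from compound 3 by methoxy in place of fluoro on an aromatic carbon. Within the data shown here, no measured step touches this place: the step from compound 1 to compound 2 alters a different ring of the core, so it bears on the present change only loosely. With nothing to point to a shift, a step within the scatter is expected, a 1.0-fold higher number from compound 3 to compound 4 (0.01 log units; within the scatter), while the wide range allows for a modest move either way. Compound 4 is therefore expected to give about 8000 nM in this assay, between 3000 nM and 25000 nM.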

Compound 4, half-maximal inhibitory concentration: 14600 nM
The estimate for compound 4 lay 1.8-fold (0.26 log units) below the measured number; measured number inside the range.
By their numbers in this assay, from the lowest: compounds 1, 3 and 4 (each within the scatter of the next, the first and the last beyond it). At a limit, above all of these: compound 2.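

In this assay, within the data shown here, the first measured change at this position, 4-fluorophenyl to 4-methoxyphenyl, gives a 1.9-fold higher number from compound 3 to compound 4 (0.27 log units; within the scatter) and so cannot be told apart from repeat measurement. The earlier compounds shown here showed a step only on the aniline part of the shared core; this one shows that, with the aniline part of compound 3 held fixed, methoxy can stand in place of fluoro on this ring without a shift beyond the scatter. Nothing in the available evidence bears on this step.

The compounds shown leave open whether an amine, a hydroxyl or a longer chain such as butoxy at this place would move the number beyond the scatter. They also leave open whether the same exchange would read alike with the aniline part of compound 1.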